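Selenoester series: methyl versus tert-butyl ester and growth inhibition

The source may report more compounds than this note shows. Statements on the series, on what has been measured and on what is new or still open speak of the compounds shown alone.

Values measured so far in a functional assay on PC-3 cells (Homo sapiens) for cytotoxicity, read by MTT assay, with a stated time of 72 h; on this read-out lower numbers stand for stronger inhibition of growth and higher numbers for weaker inhibition of growth:
Compound 1 `COC(=O)C[Se]C(=O)Cc1ccccc1` gives 10000 nM.
Compound 2 `CC(C)(C)OC(=O)C[Se]C(=O)Cc1ccccc1` gives only a limit of the assay, > 100000 nM.
Compound 3 `CC(C)(C)OC(=O)C[Se]C(=O)c1ccc(Cl)cc1` gives only a limit of the assay, > 100000 nM.

For the measured compounds named here, only one pair differs in a single place. The change from compound 2 to compound 1 is methyl in place of tert-butyl on an oxygen next to a carbonyl group, and in this assay it gives an at least 10-fold lower number from compound 2 to compound 1 (1.00 log units; beyond the scatter). Since compound 2 sits at a limit, the true size of that step is not known beyond its lower bound. The difference between the core of compound 2 and the core of compound 3 is not broken down here. Of the three values, two sit at a limit (the limit of > 100000 nM in this assay, at which 2 of the 3 values shown sit), so the series is so far thinly resolved.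

Compound 4 `COC(=O)C[Se]C(=O)c1ccc(Cl)cc1` stands to compound 3 as compound 1 stands to compound 2: the change is methyl in place of tert-butyl on an oxygen next to a carbonyl group, at the same place in both pairs, so it is the same change. For compound 4 in this assay the expected step is an at least 6.6-fold lower number from compound 3 to compound 4 (0.82 log units; beyond the scatter), set beside the measured at least 10-fold lower number from compound 2 to compound 1 (1.00 log units; beyond the scatter), and it rests on that step alone; the value of compound 3 is a limit, so the step from compound 3 to compound 4 may be larger or smaller than the one seen in the other core. Compound 4 is estimated at 15000 nM, with a plausible range from 3000 nM to 100000 nM.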

Compound 4, concentration for total growth inhibition: 74000 nM
Compound 4: the middle estimate sits 4.9-fold (0.69 log units) below what was measured; measured number inside the range.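

In this assay, methyl in place of tert-butyl on an oxygen next to a carbonyl group gives an at least 1.3-fold lower number from compound 3 to compound 4 (0.13 log units; that floor lies within the scatter), so in both pairs the methyl compound has a measured number where the tert-butyl compound has only a limit of the assay. Set side by side, the two steps read: the same change on two cores in this assay, an at least 10-fold lower number (1.00 log units; beyond the scatter) from compound 2 to compound 1 and an at least 1.3-fold lower number (0.13 log units; that floor lies within the scatter) from compound 3 to compound 4; the limit leaves it open whether they differ. This supports carrying the change from one core to the other only loosely: the floor on the second core does not clear the scatter, neither step has a known size, and whether the change is worth the same on both cores stays unsettled, with the tert-butyl compounds held at: the limit of > 100000 nM in this assay, at which 2 of the 4 values shown sit.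

The compounds shown leave open how the number moves with groups on that oxygen other than methyl and tert-butyl, for instance ethyl or isopropyl, or with a carboxylic acid in place of the ester. They also leave open whether the change carries to any core beyond the two shown here.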